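A few compounds are considered here, and "the series" means these few. Any claim that something is new, unique, unknown or untested is made for them only; others in the source may bear on it.

Compound 1, `COc1cc(-c2nn(-c3cccc(NC(=O)Nc4cc(C(F)(F)F)cc(C(F)(F)F)c4)c3)cc2-c2ccncc2)ccc1Cl`, gives 2060 nM in a functional assay on RXF 393 cells (Homo sapiens) for inhibition, read by sulforhodamine B assay, with a stated time of 48 h; a lower number here means a stronger inhibitor of growth, a higher number a weaker inhibitor of growth.
Compound 2, `O=C(Nc1cccc(-n2cc(-c3ccncc3)c(-c3ccc(Cl)c(O)c3)n2)c1)Nc1cc(C(F)(F)F)cc(C(F)(F)F)c1`, gives 2490 nM in this assay.
Compound 3, `COc1cc(-c2nn(-c3cccc(NC(=O)Nc4ccc(Cl)c(C(F)(F)F)c4)c3)cc2-c2ccncc2)ccc1Cl`, gives 6290 nM in this assay.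

Compound 1 and compound 2 differ in one place, (hydrogen in place of methyl on an oxygen on an aromatic ring), and this change gave a 1.2-fold higher number from compound 1 to compound 2 (0.08 log units; within the scatter), so the two values stand together within the usual scatter and neither can be called the stronger of the pair. Compound 3 carries a different urea partner from compound 1; how the two cores differ is not broken down here. Of the three measured values, compound 3 gives the highest number, and the gaps to compound 2 and to compound 1 both lie beyond the scatter, so compound 3 is the weakest growth inhibitor among them in this assay.

Compound 4, `O=C(Nc1cccc(-n2cc(-c3ccncc3)c(-c3ccc(Cl)c(O)c3)n2)c1)Nc1ccc(Cl)c(C(F)(F)F)c1`, has not yet been measured. It differs from compound 3 by hydrogen in place of methyl on an oxygen on an aromatic ring, the same change already seen between compound 1 and compound 2, at a place described in the same words. Among the measured compounds shown here, because that earlier step was a 1.2-fold higher number from compound 1 to compound 2 (0.08 log units; within the scatter), a step of similar size is expected from compound 3 to compound 4, namely a 1.2-fold higher number from compound 3 to compound 4 (0.06 log units; within the scatter), which rests on the single earlier pair alone. On that basis compound 4 is estimated at 7300 nM in this assay, with a likely range from 3500 nM to 15000 nM.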

Compound 4, concentration for total growth inhibition: 1670 nM
For compound 4 the middle estimate is 4.4-fold (0.64 log units) above the measured one, and the stated range ends above it.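

In this assay the change from methoxy to hydroxy gave a 3.8-fold lower number from compound 3 to compound 4 (0.58 log units; beyond the scatter) and so made compound 4 the stronger growth inhibitor of that pair, whereas the same change left compound 1 and compound 2 within the scatter of each other. Among the compounds shown here, the change therefore did not carry over from one core to the other with a step of one size: the same change on two cores in this assay, a 1.2-fold higher number (0.08 log units; within the scatter) from compound 1 to compound 2 and a 3.8-fold lower number (0.58 log units; beyond the scatter) from compound 3 to compound 4, 4.6-fold (0.66 log units) apart, beyond the scatter of two such steps This shows that, in these two pairs, the effect of swapping 4-chloro-3-methoxyphenyl for 4-chloro-3-hydroxyphenyl depended on the core that carried it, but it does not show why the steps differ, and with only two pairs it gives no rule for any further core.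

The compounds shown leave open whether a third urea partner would follow the pair of compound 1 and compound 2 or the pair of compound 3 and compound 4. They also leave open how other groups on that oxygen or in its place on the aromatic ring, such as an ethyl chain, an amine or a carboxylic acid, would behave on these two cores.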